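Swapping 4-methylphenyl for cyclohexyl in a Jurkat activator

A few compounds are considered here, and "the series" means these few. Any claim that something is new, unique, unknown or untested is made for them only; others in the source may bear on it.

Measured so far:
compound 1 `CN(Cc1ccccc1O)c1ccc(C2CCCCC2)cc1`: "not active" (no number reported)
compound 2 `Oc1cc(I)ccc1CNc1ccc(C2CCCCC2)cc1`: "not active" (no number reported)
compound 3 `Cc1ccc(-c2ccc(NCc3ccccc3O)cc2)cc1`: 3790 nM

Of the compounds shown here, three have been tested in a functional assay on Jurkat cells (Homo sapiens) for activation, with a stated time of 24 h; a lower number here means that less compound is needed, a higher number that more compound is needed for the effect. Compound 1 returned "not active" (no number reported), and compound 2 likewise returned "not active" (no number reported); neither gives a number. Going by the values given here, compound 3 is the only one with a reported value, 3790 nM in this assay, so it stands alone as the single point of reference, and a weak one. Compound 4 `Oc1ccccc1CNc1ccc(C2CCCCC2)cc1` has not yet been measured. It differs from compound 3 in one place: cyclohexyl in place of 4-methylphenyl on an aromatic carbon. Compound 4 shares its cyclohexyl group with compound 1 and compound 2, both of which gave no number in this assay, though each of those also carries a further change that compound 4 lacks. Among the compounds with values here, no step between two measured compounds is available to size this change. The account expects the number for compound 4 in this assay to rise beyond the scatter, because cyclohexyl-bearing compound 1 with "not active" (no number reported) and compound 2 with "not active" (no number reported) showed no activity, and a step of a 2.1-fold higher number from compound 3 to compound 4 (0.32 log units; beyond the scatter) is therefore expected. Compound 4 is estimated at 8000 nM, in a range of 2500 nM to 30000 nM, with a real chance that no number is reported at all.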

Compound 4, half-maximal effective concentration: 8800 nM
Estimate against measurement, compound 4: 1.1-fold (0.04 log units) below, within the range that was stated.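

In this assay, the step of a 2.3-fold higher number from compound 3 to compound 4 (0.37 log units; beyond the scatter) gives the first size for cyclohexyl in place of 4-methylphenyl on an aromatic carbon: a modest change, though beyond the scatter, so this position accepts a non-aromatic ring at some cost but without losing a measurable number. It also shows that cyclohexyl alone does not abolish the effect, since compound 4 gives 8800 nM, whereas compound 1 gives "not active" (no number reported) and compound 2 gives "not active" (no number reported); the steps to those two cannot be read, but their missing numbers must involve the further change each carries, alone or together with cyclohexyl. No measurement shown here explains why the swap costs what it does.

The compounds shown leave open how other groups would behave at this position, such as an unsubstituted phenyl, a tert-butyl or a carboxylic acid. They also leave open whether the further changes in compound 1 and compound 2 would be tolerated alongside 4-methylphenyl rather than cyclohexyl.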